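The compounds below may be only part of what the source reports. "The series", "measured", "known", "first", "only" and "open" are said of these compounds alone.

Measured in a functional assay on A549 cells (Homo sapiens) for inhibition, read by MTT assay, with a stated time of 48 h; on this read-out lower numbers stand for stronger inhibition and higher numbers for weaker inhibition:
- compound 1 `COc1cc(-c2cc(=O)[nH]c3c(O)c(OC)ccc23)cc([Se]C)c1OC`: 60.7 nM
- compound 2 `COc1cc(-c2cc(=O)[nH]c3c(O)c(OC)ccc23)cc(SC)c1OC`: 61.8 nM

Going by the values given here, compound 2 stands level with compound 1 in this assay, since the one measured step, a 1.0-fold higher number from compound 1 to compound 2 (0.01 log units; within the scatter), lies within the scatter. Compound 3 `COc1cc(-c2c(C)c(=O)[nH]c3c(O)c(OC)ccc23)cc(SC)c1OC` differs from compound 2 in a single place, methyl in place of hydrogen on an aromatic carbon. The measured step exchanges selenium for sulfur in a different group, so it bears on this change only by showing how closely the two known compounds agree. Among the compounds with values here, no measured compound carries this methyl, and the data therefore give neither a size nor a direction for it. The expectation stays anchored on compound 2 at 61.8 nM, leaning loosely towards a weaker result, with an estimated shift of a 1.5-fold higher number from compound 2 to compound 3 (0.16 log units; within the scatter). In this assay, compound 3 is expected at 90 nM, with an estimated range from 15 nM to 500 nM.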

Compound 3, half-maximal inhibitory concentration: 86 nM
For compound 3 the middle estimate is 1.0-fold (0.02 log units) above the measured one; low and high end bracket the measured number.
By their numbers in this assay, from the lowest: compounds 1, 2 and 3 (each within the scatter of the next).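

In this assay, methyl in place of hydrogen on this aromatic carbon, two atoms from the ring nitrogen, gives a 1.4-fold higher number from compound 2 to compound 3 (0.14 log units; within the scatter), so compound 2 and compound 3 cannot be told apart. Going by these compounds alone, this is the first sign that this position of the shared core can carry a methyl while the number stays level with that of the hydrogen compound. Nothing available explains this result.

From the compounds shown here alone, it remains open whether a larger or different group in the same place, such as an ethyl, a phenyl, an amine or a carboxylic acid, would also leave the number level. Going by these compounds, it is equally open whether this methyl would give the same result alongside the selenium-containing group of compound 1.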